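The source may report more compounds than this note shows. Statements on the series, on what has been measured and on what is new or still open speak of the compounds shown alone.

Compound 1 `Nc1cccc(-c2cn3nc(-c4ccc(F)cc4)sc3n2)c1` is the starting point. In a functional assay on FM3A cells (Mus musculus) for inhibition, read by cell counting, with a stated time of 2 days (on this read-out lower numbers stand for stronger inhibition and higher numbers for weaker inhibition), compound 1 gives 33000 nM, the highest of the three numbers measured, with compound 2 nearest and compound 3 furthest from it. Compound 2 `CCc1ccc(-c2nn3cc(-c4cccc(N)c4)nc3s2)cc1` gives 8200 nM in this assay, and compound 3 `Nc1cccc(-c2cn3nc(Cc4ccccc4)sc3n2)c1` gives 4700 nM. The two measured steps are a 4.0-fold lower number from compound 1 to compound 2 (0.60 log units; beyond the scatter) and a 7.0-fold lower number from compound 1 to compound 3 (0.85 log units; beyond the scatter); both alter the aryl end of the shared core and leave the amino group untouched.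

Compound 4 `C=C(Br)C(=O)Nc1cccc(-c2cn3nc(-c4ccc(F)cc4)sc3n2)c1` changes a different place: (1-bromoethenyl)carbonyl in place of hydrogen on a nitrogen on an aromatic ring. Neither measured step touches this nitrogen, so they offer no direct guide to its size or direction. In the absence of a precedent on this side of the molecule, a step of about a 2.8-fold lower number from compound 1 to compound 4 (0.44 log units; beyond the scatter) is expected, with wide uncertainty in either direction. Compound 4 is therefore estimated at 12000 nM in this assay, within a range of 2500 nM to 60000 nM.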

Compound 4, half-maximal inhibitory concentration: 610 nM
Estimate against measurement, compound 4: 20-fold (1.29 log units) above; the whole stated range lies above it.
By their numbers in this assay, from the lowest: compound 4; then compounds 3 and 2 (each within the scatter of the next); then compound 1.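

In this assay, the amino group proves a far more responsive place than the aryl end of the shared core: (1-bromoethenyl)carbonyl in place of hydrogen on this nitrogen gives a 54-fold lower number from compound 1 to compound 4 (1.73 log units; beyond the scatter) and this step is large, while the two changes at the aryl end were modest. The amino group therefore need not stay free on this read-out, as replacing one of its hydrogens lowers the number instead of raising it. Nothing measured here explains why the number falls so far.

Going by these compounds, it remains open which part of the entering group carries the step, a question that a plain acetyl or a (1-chloroethenyl)carbonyl on the same nitrogen could help to settle. Also open, on these data alone, is whether the same group would give a comparable step on compound 3, which carries benzyl in place of 4-fluorophenyl.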